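Chloro position on the aryl urea and thiourea arm

A few compounds are considered here, and "the series" means these few. Any claim that something is new, unique, unknown or untested is made for them only; others in the source may bear on it.

Measured compounds in a functional assay on thoracic aorta (Rattus norvegicus) for inhibition; a lower number here means that less compound is needed, a higher number that more compound is needed for the effect:
- compound 1 `CC1(C)CC(NC(=O)Nc2cccc(Cl)c2)c2cc(NS(C)(=O)=O)ccc2O1` gives 15200 nM.
- compound 2 `CC1(C)CC(NC(=O)Nc2ccc(Cl)cc2)c2cc(NS(C)(=O)=O)ccc2O1` sits at a limit of the assay, > 30000 nM.
- compound 3 `CCS(=O)(=O)Nc1ccc2c(c1)C(NC(=S)Nc1cccc(Cl)c1)CC(C)(C)O2` gives 9800 nM.

For the measured compounds named here, the one counted step, (4-chlorophenyl in place of 3-chlorophenyl on an amide-type nitrogen), gives an at least 1.9-fold higher number from compound 1 to compound 2 (0.29 log units; that floor lies within the scatter). The difference between the core of compound 1 and the core of compound 3 is not broken down here; their two values lie within the scatter of each other.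

Compound 4 `CCS(=O)(=O)Nc1ccc2c(c1)C(NC(=S)Nc1ccc(Cl)cc1)CC(C)(C)O2` is not yet measured. It carries 4-chlorophenyl in place of 3-chlorophenyl on an amide-type nitrogen, the same kind of change as from compound 1 to compound 2, but the nitrogen's other neighbour is a thiocarbonyl carbon rather than a carbonyl carbon. Resting on an at least 1.9-fold higher number from compound 1 to compound 2 (0.29 log units; that floor lies within the scatter), the step of a 2.4-fold higher number from compound 3 to compound 4 (0.39 log units; beyond the scatter) is expected. Compound 4 is estimated at 24000 nM, between 10000 nM and 60000 nM, with a fair chance that only a limit is reported.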

Compound 4, half-maximal effective concentration: 5100 nM
The estimate for compound 4 lay 4.7-fold (0.67 log units) above the measured number; the measured number lies below the stated range.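

In this assay, 4-chlorophenyl in place of 3-chlorophenyl on the core of compound 3 gives a 1.9-fold lower number from compound 3 to compound 4 (0.28 log units; within the scatter), and the change does not carry over between the two cores as a fixed shift: the same change on two cores in this assay, an at least 1.9-fold higher number (0.29 log units; that floor lies within the scatter) from compound 1 to compound 2 and a 1.9-fold lower number (0.28 log units; within the scatter) from compound 3 to compound 4, at least 3.7-fold (0.57 log units) apart, beyond the scatter of two such steps

Compound 2 stands at a limit of the assay, > 30000 nM, not at a number.

The data do not show which difference between the cores goes with this gap, the thiocarbonyl in place of the carbonyl or the ethyl in place of the methyl on the sulfonyl group.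

A urea carrying the ethyl sulfonyl group, or a thiourea carrying the methyl sulfonyl group, would separate these two differences. Also open, as far as these compounds go, is whether a nitrile or a methoxy group in place of the chlorine behaves in the same way on either core.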